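A few compounds are considered here, and "the series" means these few. Any claim that something is new, unique, unknown or untested is made for them only; others in the source may bear on it.

In a functional assay on A2780 cells (Homo sapiens) for inhibition (a lower number here means a stronger inhibitor, a higher number a weaker inhibitor), compound 1 `CCNC(=O)c1noc(-c2cc(C(C)C)c(O)cc2O)c1-c1cc(CO)no1` gives 5 nM, the lowest number among the three measured compounds, so it is the strongest inhibitor of the set. Compound 2 `CCNC(=O)c1noc(-c2cc(C(C)C)c(O)cc2O)c1-c1cc(CNC(C)C)no1` gives 38 nM in this assay, and compound 3 `CCNC(=O)c1noc(-c2cc(C(C)C)c(O)cc2O)c1-c1cn[nH]c1` gives 38 nM. Both changes away from compound 1 weakened inhibition to a modest degree: a 7.6-fold higher number from compound 1 to compound 2 (0.88 log units; beyond the scatter) and a 7.6-fold higher number from compound 1 to compound 3 (0.88 log units; beyond the scatter). The unmeasured compound 4 `CCNC(=O)c1noc(-c2cc(C(C)C)c(O)cc2O)c1-c1cnn(CC)c1` differs from compound 1 in one place: 1-ethyl-1H-pyrazol-4-yl in place of 3-(hydroxymethyl)-1,2-oxazol-5-yl on an aromatic carbon. For the measured compounds named here, the step that bears most directly on this is the one from compound 1 to compound 3, where the same 3-(hydroxymethyl)-1,2-oxazol-5-yl group left and a 1H-pyrazol-4-yl group entered; the 1-ethyl-1H-pyrazol-4-yl group of compound 4 differs from that only by its ethyl, for which no measured step exists. The expectation therefore rests on compound 3 and is a modest weakening, not none. Compound 4 is expected to show an 8.0-fold higher number from compound 1 to compound 4 (0.90 log units; beyond the scatter). For compound 4 the estimated value in this assay is 40 nM, with a range from 15 nM to 120 nM.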

Compound 4, half-maximal inhibitory concentration: 30 nM
Estimate against measurement, compound 4: 1.3-fold (0.12 log units) above; the measured number falls inside the stated range.
By their numbers in this assay, from the lowest: compound 1; then compounds 4, 2 and 3 (each within the scatter of the next).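

In this assay the aromatic nitrogen of the pyrazole accepts ethyl in place of hydrogen with no change that can be read: the data show a 1.3-fold lower number from compound 3 to compound 4 (0.10 log units; within the scatter) and so this added group neither helps nor harms within the scatter of the assay. The pyrazole therefore stays short of the 3-(hydroxymethyl)-1,2-oxazol-5-yl group whether or not it carries the ethyl, with a 6.0-fold higher number from compound 1 to compound 4 (0.78 log units; beyond the scatter) and a gap beyond the scatter, while the comparison with the other 1,2-oxazole gives a 1.3-fold lower number from compound 2 to compound 4 (0.10 log units; within the scatter) and so cannot separate those two groups. Still open, on these data alone, is whether a longer chain on that nitrogen, such as n-propyl, or a chain ending in a hydroxyl or an amine, such as 2-hydroxyethyl or 2-aminoethyl, would close the gap to compound 1. Nothing measured here explains why these groups give the numbers they do.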